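The source may report more compounds than this note shows. Statements on the series, on what has been measured and on what is new or still open speak of the compounds shown alone.

Compound 1 `Cc1cc(NC(=O)Nc2ccc(C(C)(C)C)cc2)c2ccccc2n1`: 20000 nM
Compound 2 `Cc1cc(NC(=O)Nc2cc(F)cc(F)c2)c2ccccc2n1`: > 25000 nM

Of the compounds shown here, two sharing the same core have been measured so far. For the measured compounds named here, in an ADME assay on BJ cells (Homo sapiens) for cytotoxicity, with a stated time of 72 h (a higher number here means that more compound is needed for the effect, a lower number that less compound is needed), compound 1 gives 20000 nM, the only plain number among the two values shown. Compound 2 gives > 25000 nM, which is a limit of the assay and not a number; that is the limit of > 25000 nM in this assay, at which 1 of the 2 values shown sits. Going by the values given here, no step between measured compounds that differ in one place is available, so nothing measured tells how a single change at one point of the structure moves the read-out here.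

Compound 3 `Cc1cc(NC(=O)Nc2ccc(N)cc2)c2ccccc2n1` has not yet been tested in this assay. It differs from compound 1 by one change: amino in place of tert-butyl on an aromatic carbon. Without a measured step to lean on, the step from compound 1 to compound 3 is expected to be small, if anything toward a higher value, and possibly no larger than the scatter. Compound 3 is therefore estimated at 25000 nM, within a range of 10000 nM to 60000 nM. This estimate means an expected step of a 1.3-fold higher number from compound 1 to compound 3 (0.10 log units; within the scatter), and it is likely that only a limit will be reported.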

Compound 3, half-maximal effective concentration: > 25000 nM
Compound 3 ended at the assay's limit; the forecaster's own chance of this, stated with the estimate: 60%; the middle value lies on the limit itself.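

In this assay, the exchange of tert-butyl for amino on the aromatic carbon, para to a large group, gives the first step measured at this position: an at least 1.2-fold higher number from compound 1 to compound 3 (0.09 log units; that floor lies within the scatter). On these data alone, the value of compound 3 is a limit of the assay and not a number, so this step is only a floor, and its true size remains unknown. Even so, replacing a group of four carbons with a single nitrogen that brings in a hydrogen-bond donor and acceptor gives no sign of a lower number here, and the plain value of compound 1 remains the only number among the results, with the others gathered at the limit: the limit of > 25000 nM in this assay, at which 2 of the 3 values shown sit.

The compounds shown leave open how far compound 3 lies beyond the limit, and whether any group at this position can move the read-out clearly below that of compound 1. For the compounds shown here, a carboxylic acid, a methoxy group or a longer alkyl chain on the same aromatic carbon would extend the comparison beyond the single pair of tert-butyl and amino.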